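The source may hold more compounds than are shown below. What is called first, only, known or untested is meant among the compounds shown, and "the series" means these compounds.

Measured so far in a physicochemical assay for lipophilicity; on this read-out lower numbers stand for lower lipophilicity and higher numbers for higher lipophilicity:

compound 1, `CCN1C(=O)CN(Cc2ccc(-c3cccc(CN4CCCCC4)n3)cc2)C1=O`: 1.7
compound 2, `CCN1C(=O)CN(Cc2ccc(-c3ccc(F)c(CN4CCCCC4)n3)cc2)C1=O`: 2.1
compound 3, `CC(C)CN1C(=O)CN(Cc2ccc(-c3ccc(F)c(CN4CCCC(C)C4)n3)cc2)C1=O`: 3.9

Compound 1 holds the lowest of the three numbers. Its nearest neighbour is compound 2, reached by the step of a number 0.40 log units higher from compound 1 to compound 2 (beyond the scatter), a shift beyond the scatter. Compound 3 stands much higher still, but it differs from compound 1 in several places at once, so its number alone is all that can be said of that pair.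

Compound 4, `CN1C(=O)CN(Cc2ccc(-c3cccc(CN4CCCCC4)n3)cc2)C1=O`, differs from compound 1 in one place only: hydrogen in place of methyl on a saturated chain carbon bound to an amide-type nitrogen in a ring. Cut one bond further out, the change reads ethyl to methyl.

Among the measured compounds shown here, no measured step removes a single chain carbon in this way; the one single-place step known, a number 0.40 log units higher from compound 1 to compound 2 (beyond the scatter), concerns a fluoro on an aromatic carbon and does not bear directly on the present change. Loss of one carbon from a saturated chain is expected to move the number down by a small amount, around the edge of the scatter. For compound 4 the expected step is therefore a number 0.40 log units lower from compound 1 to compound 4 (beyond the scatter). Compound 4 is estimated to give 1.3 in this assay, within a range of 0.9 to 1.7.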

Compound 4, distribution coefficient: 1.3
Compound 4: middle estimate and measured number agree at the digits printed; the measured number falls inside the stated range.
By their numbers in this assay, from the lowest: compound 4; then compound 1; then compound 2; then compound 3.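

Notes on the series: in this assay the step of a number 0.40 log units lower from compound 1 to compound 4 (beyond the scatter) is the first single-place reading at the saturated chain carbon bound to an amide-type nitrogen in a ring. Up to now, the only single-place step concerned fluoro on an aromatic carbon, so this shows that the read-out also responds at this second place, and that the loss of a single methyl is enough to carry the number beyond the scatter. Nothing at hand accounts for this step.

Open, from the compounds shown here alone, is how the number runs at this place with a propyl chain, a chain ending in a hydroxyl group or a chain ending in a carboxylic acid. Also open, going by these compounds, is whether ethyl to methyl gives a step of like size on compound 2, which carries the fluoro.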